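Methoxy in Place of Methyl on the Aryl Ring

A few compounds are considered here, and "the series" means these few. Any claim that something is new, unique, unknown or untested is made for them only; others in the source may bear on it.

Compound 1 `O=C1c2ccccc2C(=O)N1c1nc(-c2ccc(F)cc2)cs1` in a functional assay on PC-3 cells (Homo sapiens) for antiproliferative activity, read by MTT assay, with a stated time of 48 h (on this read-out higher numbers stand for weaker inhibition and lower numbers for stronger inhibition), gives 37200 nM; compound 2 `Cc1ccc(-c2csc(N3C(=O)c4ccccc4C3=O)n2)cc1` in this assay gives 38400 nM.

On these two numbers compound 2 holds the upper one, yet the step of a 1.0-fold higher number from compound 1 to compound 2 (0.01 log units; within the scatter) is within the scatter, so the two compounds are not separated. Compound 3 `COc1ccc(-c2csc(N3C(=O)c4ccccc4C3=O)n2)cc1` differs from compound 2 by methoxy in place of methyl on an aromatic carbon. Among the measured compounds shown here, no measured step covers this change; the only step seen, fluoro to methyl, stayed within the scatter. A step within the scatter is therefore expected, a 1.0-fold lower number from compound 2 to compound 3 (0.00 log units; within the scatter). Compound 3 is estimated at 38000 nM, between 15000 nM and 100000 nM.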

Compound 3, half-maximal inhibitory concentration: 42900 nM
Beside the measured number, compound 3's estimate is 1.1-fold (0.05 log units) below it; low and high end bracket the measured number.
By their numbers in this assay, from the lowest: compounds 1, 2 and 3 (each within the scatter of the next).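

In this assay the methoxy group, which adds a hydrogen-bond acceptor that methyl and fluoro lack, gives a 1.1-fold higher number from compound 2 to compound 3 (0.05 log units; within the scatter) and a 1.2-fold higher number from compound 1 to compound 3 (0.06 log units; within the scatter) without separating the compounds. Three different groups on this aromatic carbon, para to a large group, now cannot be told apart, so the earlier null step was not special to fluoro and methyl. No available evidence explains this flat result. The compounds shown leave open whether an amine, a carboxylic acid or a longer chain at this position would depart from these three values. They also leave open how any change to the shared core would read.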